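Swapping the amine substituent toward an indole

The source may hold more compounds than are shown below. What is called first, only, known or untested is meant among the compounds shown, and "the series" means these compounds.

Compound 1 `COc1ccc(N/C=C\C(=O)c2nc(-c3ccc(F)cc3)n3ccccc23)cc1` is the starting point. In a functional assay on MDA-MB-231 cells (Homo sapiens) for cytotoxicity, read by MTT assay, with a stated time of 48 h (a lower number here means a stronger inhibitor, a higher number a weaker inhibitor), compound 1 gives only a limit, > 30000 nM, rather than a number. Compound 2 `COc1ccc(N/C=C\C(=O)c2nc(-c3ccc(OC)cc3)n3ccccc23)cc1` is a close relative in which a methoxy replaces the fluoro on an aromatic carbon of the aryl attached to the shared core, and compound 2 likewise gives only the limit > 30000 nM in this assay. Compound 3 `COc1ccc(N/C=C\C(=O)c2nc(-c3ccccc3)n3ccccc23)cc1` carries a hydrogen at that same aromatic carbon and in this assay gives 28300 nM. The steps measured so far are a step that the two limits leave unreadable from compound 1 to compound 2, an at least 1.0-fold lower number from compound 1 to compound 3 (0.02 log units; that floor lies within the scatter) and an at least 1.0-fold lower number from compound 2 to compound 3 (0.02 log units; that floor lies within the scatter), so nothing among the three measured compounds moves clearly beyond the scatter, and two of the three values rest at the limit of > 30000 nM in this assay, at which 2 of the 3 values shown sit.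

Compound 4 `Cc1cc2cc(N/C=C\C(=O)c3nc(-c4ccc(F)cc4)n4ccccc34)ccc2[nH]1` differs from compound 1 at a different place: 2-methyl-1H-indol-5-yl in place of 4-methoxyphenyl on an amine nitrogen. For the measured compounds named here, none of the measured steps touches this nitrogen, so they offer no direct guide to the size or direction of the change. With all three measured compounds sitting at or near the limit, compound 4 is expected to land in the same weak region, and the expected step from compound 1 to compound 4 is an at least 1.2-fold lower number from compound 1 to compound 4 (0.07 log units; that floor lies within the scatter). The estimate for compound 4 in this assay is therefore 25000 nM, with a range from 8000 nM to 80000 nM.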

Compound 4, half-maximal inhibitory concentration: > 30000 nM
Compound 4 gave a limit, no number; the forecaster's own chance of this, stated with the estimate: 45%; middle value at least 1.2-fold (0.07 log units) away from the limit.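

In this assay compound 4 gives > 30000 nM, a limit and not a number. Compound 1 also stands at a limit, so no step between compound 1 and compound 4 can be read, and most values rest at one point: the limit of > 30000 nM in this assay, at which 3 of the 4 values shown sit.

The compounds shown leave open whether 2-methyl-1H-indol-5-yl in place of 4-methoxyphenyl on the amine nitrogen changes the result at all, and in which direction.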